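Cytotoxicity Outlook for a Furan Amide

The source may report more compounds than this note shows. Statements on the series, on what has been measured and on what is new or still open speak of the compounds shown alone.

In an ADME assay on IMR-90 cells (Homo sapiens) for cytotoxicity, read by CellTiter-Blue, with a stated time of 46 h (on this read-out lower numbers stand for an effect already at smaller amounts and higher numbers for an effect only at larger amounts of compound), compound 1 (`O=C(Nc1ccc(S(=O)(=O)N2CCC(F)CC2)cc1)c1ccc([N+](=O)[O-])o1`) gives only a limit, > 25000 nM. Compound 2 (`CC1(C)CCN(S(=O)(=O)c2cccc(NC(=O)c3ccc([N+](=O)[O-])s3)c2)CC1`) likewise gives only a limit in this assay, > 25000 nM. Compound 2 thus stands at the limit of > 25000 nM in this assay, at which 2 of the 2 values shown sit, so no number places it against compound 1. Compound 3 (`CC1(C)CCN(S(=O)(=O)c2cccc(NC(=O)c3ccco3)c2)CC1`) differs from compound 2 by furan-2-yl in place of 5-nitrothiophen-2-yl on a carbonyl carbon. Within the data shown here, no measured step shows this change; for compound 3 the expected step from compound 2 to compound 3 is none beyond the scatter, a number no higher from compound 2 to compound 3 (the limit leaves the size open), most likely again a limit. For compound 3 the estimate is 25000 nM, within 10000 nM to 60000 nM.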

Compound 3, half-maximal effective concentration: > 25000 nM
Compound 3: no number, only a limit; the forecaster's own chance of this, stated with the estimate: 80%; the middle value lies on the limit itself.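

Compound 2 and compound 3 both give only a limit in this assay, so no step can be read between them: the limit of > 25000 nM in this assay, at which 3 of the 3 values shown sit. The compounds shown leave open whether furan-2-yl in place of 5-nitrothiophen-2-yl on a carbonyl carbon changes the read-out at all.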